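The source may hold more compounds than are shown below. What is called first, only, known or untested is meant among the compounds shown, and "the series" means these compounds.

Compound 1 `O=[N+]([O-])c1ccc(-c2cn(Cc3ccccc3)nn2)cc1` carries a nitro group on its outer ring. In a functional assay on B16 cells (Mus musculus) for cytotoxicity, read by MTT assay, with a stated time of 48 h (on this read-out lower numbers stand for stronger inhibition and higher numbers for weaker inhibition), compound 1 gives 5120 nM. Compound 2 `Cc1ccc(-c2cn(Cc3ccccc3)nn2)cc1` differs from compound 1 by methyl in place of nitro on an aromatic carbon. For compound 2 this assay reports only a limit, > 100000 nM, and no number, (the limit of > 100000 nM in this assay, at which 1 of the 3 values shown sits). That exchange therefore brought an at least 19-fold higher number from compound 1 to compound 2 (1.29 log units; beyond the scatter). Compound 3 `COc1cccc(Cn2cc(-c3ccc([N+](=O)[O-])cc3)nn2)c1` keeps the core of compound 1 and differs from it by methoxy in place of hydrogen on an aromatic carbon; in this assay compound 3 gives 19100 nM, which is a 3.7-fold higher number from compound 1 to compound 3 (0.57 log units; beyond the scatter). Compound 4 `COc1cccc(Cn2cc(-c3ccc(C)cc3)nn2)c1` has not yet been measured. Going by the values given here, it differs from compound 3 by methyl in place of nitro on an aromatic carbon, the same change at the same place as the one separating compound 2 from compound 1. Compound 4 is expected to show a 10-fold higher number from compound 3 to compound 4 (1.02 log units; beyond the scatter), because the same exchange earlier gave an at least 19-fold higher number from compound 1 to compound 2 (1.29 log units; beyond the scatter). Compound 4 is therefore estimated at 200000 nM, most likely between 60000 nM and 700000 nM, and it may well again come out only as a limit of this assay rather than a number.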

Compound 4, half-maximal inhibitory concentration: 19500 nM
For compound 4 the middle estimate is 10-fold (1.01 log units) above the measured one; the measured number lies below the stated range.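

In this assay, methyl in place of nitro on the core carrying the methoxy group gave a 1.0-fold higher number from compound 3 to compound 4 (0.01 log units; within the scatter), so the large shift seen on the core of compound 1 did not carry over to this second core: the same change on two cores in this assay, an at least 19-fold higher number (1.29 log units; beyond the scatter) from compound 1 to compound 2 and a 1.0-fold higher number (0.01 log units; within the scatter) from compound 3 to compound 4, at least 19-fold (1.28 log units) apart, beyond the scatter of two such steps. Methoxy in place of hydrogen also failed to carry over, giving an at least 5.1-fold lower number from compound 2 to compound 4 (0.70 log units; beyond the scatter), which runs in the opposite direction to its step among the nitro compounds: the same change on two cores in this assay, a 3.7-fold higher number (0.57 log units; beyond the scatter) from compound 1 to compound 3 and an at least 5.1-fold lower number (0.70 log units; beyond the scatter) from compound 2 to compound 4, at least 19-fold (1.28 log units) apart, beyond the scatter of two such steps. Across these four compounds, the result of each change depends on the other group present, but this does not show why, and compound 2 is a limit of the assay rather than a number, so the true size of its steps is unknown: the limit of > 100000 nM in this assay, at which 1 of the 4 values shown sits.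

From the compounds shown here alone, it remains open whether an amine or a carboxylic acid in place of nitro would behave more like nitro or like methyl. Going by these compounds, it is also open whether a longer chain in place of methoxy would show the same dependence on the other group.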